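The compounds below may be only part of what the source reports. "The series", "measured", "known", "first", "only" and "open" are said of these compounds alone.

Measured so far:
- compound 1, `O=C(CN1CCN(c2ccccn2)CC1)Nc1cccnc1`: 2660 nM
- compound 2, `Cc1ccc(C2CCN(CC(=O)Nc3cccc(C)c3)CC2)nc1`: "not active" (no number reported)
- compound 3, `Cc1ccc(C2CCN(CC(=O)Nc3cccc(C)c3)CC2)cc1`: "not active" (no number reported)

For the measured compounds named here, in an assay on cells for agonist activity at D(4) dopamine receptor (Homo sapiens), read by luminescence and beta-arrestin recruitment, with a stated time of 90 min (a higher number here means that more compound is needed for the effect, a lower number that less compound is needed), compound 1 gives 2660 nM and is the only member of the set with a numerical read-out. Compound 2 is reported as "not active" (no number reported). Going by the values given here, compound 3 is likewise reported as "not active" (no number reported), so it stands without a number; it shares this outcome with compound 2, and no step between any two measured compounds can be computed from the entries given.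

The next compound, compound 4 with structure `Cc1cccc(NC(=O)CN2CCC(c3ccccc3)CC2)c1`, arises from compound 3 by the change (hydrogen in place of methyl on an aromatic carbon), in words hydrogen in place of methyl on an aromatic carbon, on a six-membered aromatic ring of carbon only, para to a large group; cut one bond further out it reads 4-methylphenyl to phenyl. Among the compounds with values here, no measured pair in this set shows the effect of such a change, so the size and direction of the step in this assay cannot be taken from the data; the expectation rests only on compound 3 having no reported number and compound 1 carrying the single value in the set.

For compound 4 in this assay the estimate is 12000 nM, with a range from 2500 nM to 60000 nM, and a substantial chance that only a limit is reported again.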

Compound 4, half-maximal effective concentration: 242 nM
For compound 4 the middle estimate is 50-fold (1.70 log units) above the measured one; the whole stated range lies above it.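

In this assay, for the compounds shown here, compound 4 gives 242 nM, while compound 3 carries no number, so no step between compound 3 and compound 4 can be read. The compounds shown leave open how large the change from 4-methylphenyl to phenyl is in this series. No available evidence bears on this result.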